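The source may report more compounds than this note shows. Statements on the series, on what has been measured and on what is new or still open speak of the compounds shown alone.

Compound 1 `COc1ccc(-c2ss/c(=N/O)c2-c2cc(OC)c(OC)c(OC)c2)cc1N` gives 4300 nM in a functional assay on SGC-7901 cells (Homo sapiens) for antiproliferative activity, read by MTT assay, with a stated time of 72 h; on this read-out lower numbers stand for stronger inhibition and higher numbers for weaker inhibition. Compound 2 `COc1ccc(-c2c(-c3cc(OC)c(OC)c(OC)c3)ss/c2=N/O)cc1[N+](=O)[O-]` gives 6560 nM in this assay. Compound 3 `CO/N=c1/ssc(-c2ccc(OC)c(N)c2)c1-c1cc(OC)c(OC)c(OC)c1` reaches only a limit of this assay, > 100000 nM.

Compound 1 and compound 2 lie within the scatter of each other, so no order is drawn between them; how their two cores differ is not broken down here. From compound 1 to compound 3 the change is methyl in place of hydrogen on an oxygen, and in this assay it made an at least 23-fold higher number from compound 1 to compound 3 (1.36 log units; beyond the scatter), a step that can only be given as a floor because compound 3 sits at the limit of > 100000 nM in this assay, at which 1 of the 3 values shown sits.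

Compound 4 `CO/N=c1/ssc(-c2cc(OC)c(OC)c(OC)c2)c1-c1ccc(OC)c([N+](=O)[O-])c1` differs from compound 2 by the same change, (methyl in place of hydrogen on an oxygen), at the same place. Compound 4 is therefore expected to show a step of about a 15-fold higher number from compound 2 to compound 4 (1.18 log units; beyond the scatter), resting on the loss seen from compound 1 to compound 3. Compound 4 is estimated at 100000 nM, most likely reported as a limit.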

Compound 4, half-maximal inhibitory concentration: > 100000 nM
Compound 4 ended at the assay's limit; the forecaster's own chance of this, stated with the estimate: 75%; the middle value sits exactly at the limit.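

In this assay the change from hydroxy to methoxy made an at least 15-fold higher number from compound 2 to compound 4 (1.18 log units; beyond the scatter), so the large loss seen on the core of compound 1 also appears on the core of compound 2. Compound 4 gives > 100000 nM, which is a limit of the assay, so this step is only a floor. The result shows that the change carries over in direction between these two cores, but it does not show that it carries over by the same amount: the same change on two cores in this assay, an at least 23-fold higher number (1.36 log units; beyond the scatter) from compound 1 to compound 3 and an at least 15-fold higher number (1.18 log units; beyond the scatter) from compound 2 to compound 4; the limit leaves it open whether they differ

The compounds shown leave open whether an ethyl group, a longer chain or an acetyl group on this oxygen would also bring such a loss. They also leave open whether the loss would appear on any further core.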